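Floxuridine amino-acid esters: growth inhibition on MDA-MB-231 cells

A few compounds are considered here, and "the series" means these few. Any claim that something is new, unique, unknown or untested is made for them only; others in the source may bear on it.

Two esters of a shared core have been measured. Compound 1 `N[C@@H](CC(=O)OC[C@H]1O[C@@H](n2cc(F)c(=O)[nH]c2=O)C[C@@H]1O)C(=O)O` gives in a functional assay on MDA-MB-231 cells (Homo sapiens) for inhibition, read by MTT assay, with a stated time of 24 h (on this read-out higher numbers stand for weaker inhibition of growth and lower numbers for stronger inhibition of growth), a value of 29300000 nM; compound 2 `N[C@@H](CCC(=O)O[C@H]1C[C@H](n2cc(F)c(=O)[nH]c2=O)O[C@@H]1CO)C(=O)O` gives in this assay a value of 34900000 nM, and the two numbers lie within the scatter of each other, so neither stands apart. Compound 3 `CC(C)[C@H](N)C(=O)OC[C@H]1O[C@@H](n2cc(F)c(=O)[nH]c2=O)C[C@@H]1O` carries the change (1-amino-2-methylpropyl in place of 2-amino-2-carboxyethyl on a carbonyl carbon). For the measured compounds named here, no measured pair shows such a step, so for this assay the expected step of a 1.0-fold higher number from compound 1 to compound 3 (0.01 log units; within the scatter) is none beyond the scatter. Compound 3 is therefore estimated at 30000000 nM, with a range from 8000000 nM to 100000000 nM.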

Compound 3, concentration for 50% growth inhibition: 38100000 nM
Compound 3: the middle estimate sits 1.3-fold (0.10 log units) below what was measured; measured number inside the range.
By their numbers in this assay, from the lowest: compounds 1, 2 and 3 (each within the scatter of the next).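

Replacing 2-amino-2-carboxyethyl with 1-amino-2-methylpropyl on a carbonyl carbon gives, in this assay, a 1.3-fold higher number from compound 1 to compound 3 (0.11 log units; within the scatter). This first measured step at this position shows that this swap, which removes the carboxylic acid, leaves the number within the scatter. Nothing available explains this result. Still open, as far as these compounds go, is whether a longer chain or a benzyl group on this carbonyl carbon would move the number beyond the scatter, and whether the same holds for a group without the amine.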